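A few compounds are considered here, and "the series" means these few. Any claim that something is new, unique, unknown or untested is made for them only; others in the source may bear on it.

Three compounds have values in an ADME assay (liver) for metabolic stability, with Liver microsome (Homo sapiens) as the target, read by LC-MS, using microsomes, with a stated time of 1 h, tested at 5 uM (a lower number here means that less of the compound is left, a higher number that more of the compound is left), as follows
Compound 1 `Cc1nc(-c2ccccc2F)c(C(=O)N2CCN(c3cc(Cl)cc(Cl)c3)CC2)o1` gives 82.3%
Compound 2 `COc1cc(OC)cc(N2CCN(C(=O)c3oc(C)nc3-c3ccccc3F)CC2)c1` gives 15%
Compound 3 `Cc1nc(-c2cccc(F)c2)c(C(=O)N2CCN(c3cc(Cl)cc(Cl)c3)CC2)o1` gives 75.9%

Compound 2 stands lowest of the three, with the other two values well above it, beyond the usual scatter. Compound 4 `COc1cc(OC)cc(N2CCN(C(=O)c3oc(C)nc3-c3ccccc3)CC2)c1` differs from compound 2 in one place, as counted here: hydrogen in place of fluoro on an aromatic carbon (hydrogen in place of fluoro on an aromatic carbon, ortho to a large group). Within the data shown here, no measured step removes this fluoro. The closest evidence is a number 6.4 percentage points lower from compound 1 to compound 3 (within the scatter) for 3-fluorophenyl in place of 2-fluorophenyl, which lies within the scatter, although that step only relocates the fluoro. The large a number 67.3 percentage points lower from compound 1 to compound 2 (beyond the scatter) concerns a different group, 3,5-dimethoxyphenyl in place of 3,5-dichlorophenyl, and compound 2 and compound 4 both carry the 3,5-dimethoxyphenyl. No step beyond the scatter is therefore expected, in either direction. The estimated change is a number 1 percentage points lower from compound 2 to compound 4 (within the scatter) and no more. For compound 4 the expected value is 14% within an estimated range of 5% to 30% in this read-out.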

Compound 4, percent of the compound remaining: 15.8%
Compound 4: middle estimate off by 1.8 percentage points, on the low side, within the range that was stated.
By their numbers in this assay, from the lowest: compounds 2 and 4 (each within the scatter of the next); then compounds 3 and 1 (each within the scatter of the next).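

Replacing the fluoro with hydrogen gives a number 0.8 percentage points higher from compound 2 to compound 4 (within the scatter) in this assay. The earlier compounds shown here only moved the fluoro around the ring, whereas this pair takes it away, turning 2-fluorophenyl into phenyl on an aromatic carbon ortho to a large group. With 3,5-dimethoxyphenyl on the other side of the molecule, the fluoro at this place therefore makes no difference that can be told from the usual scatter. Nothing measured here speaks to why this is so.

From the compounds shown here alone, it remains open whether the same swap would be just as silent in a compound carrying 3,5-dichlorophenyl. Going by these compounds, it is also open how a different group at this place, such as a trifluoromethyl or a nitrile, would read.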